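The source may report more compounds than this note shows. Statements on the series, on what has been measured and on what is new or still open speak of the compounds shown alone.

Measured so far:
- compound 1, `Cc1cccc(C)c1Oc1nc(Nc2ccc(C#N)cc2)nc2ccccc12`: 35000 nM
- compound 2, `N#Cc1ccc(Nc2nc(Oc3ccccc3)c3ccccc3n2)cc1`: 370000 nM

Both values come from an ADME assay on MT4 cells (Homo sapiens) for cytotoxicity, read by MTT assay, with a stated time of 4 days; on this read-out lower numbers stand for higher toxicity in this test and higher numbers for lower toxicity in this test. Among the measured compounds shown here, compound 2 stands at the higher of the two numbers, and its only neighbour, compound 1, sits well apart: an 11-fold higher number from compound 1 to compound 2 (1.02 log units; beyond the scatter). Compound 3, `Cc1ccc(Oc2nc(Nc3ccc(C#N)cc3)nc3ccccc23)cc1`, has not yet been measured in this assay. It arises from compound 2 by methyl in place of hydrogen on an aromatic carbon, para to a large group. For the measured compounds named here, the one step known, from compound 1 to compound 2, concerns methyl groups on the same phenoxy ring, though two of them at other positions; it was large, and removing them raised the number. Adding a single methyl back is therefore expected to move the number somewhat downward, by a step of about a 2.5-fold lower number from compound 2 to compound 3 (0.39 log units; beyond the scatter), though smaller than the known step. Compound 3 is estimated at 150000 nM, within 50000 nM to 400000 nM.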

Compound 3, half-maximal cytotoxic concentration: 87000 nM
Estimate against measurement, compound 3: 1.7-fold (0.24 log units) above, within the range that was stated.
By their numbers in this assay, from the lowest: compound 1; then compound 3; then compound 2.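

A single methyl on the phenoxy ring, para to a large group, is enough on its own to shift the result in this assay: going to 4-methylphenoxy gives a 4.3-fold lower number from compound 2 to compound 3 (0.63 log units; beyond the scatter), which means higher toxicity in this test. The earlier step changed two methyl groups at once, so it could not show what one methyl does. The comparison with the dimethyl compound, a 2.5-fold higher number from compound 1 to compound 3 (0.40 log units; beyond the scatter), shows that 4-methylphenyl and 2,6-dimethylphenyl on the oxygen are also not equivalent, and that both give lower numbers than plain phenyl.

Nothing available explains why this methyl lowers the number. On these data alone, it also remains open whether a methoxy group, a chlorine or an amine at this place would move the number the same way, and how a single methyl elsewhere on the ring would behave.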